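Swapping the amide substituent on the shared core

This account rests on a few compounds, and the source may have more. Where it says the series, first, only, none or still open, it means among the compounds named here.

Compound 1 `CN(C)S(=O)(=O)c1ccccc1Nc1cc(-c2ccc3ccn(C)c3c2)c2nccnc2c1` gives 0.233 h in an ADME assay on microsomes from liver (Mus musculus, strain CD-1) for metabolic stability, read by LC-MS, tested at 2 uM (a lower number here means that the compound disappears faster, a higher number that the compound lasts longer), and compound 2 `CN1CCC(NC(=O)c2ccncc2Nc2cc(-c3ccc4ccn(C)c4c3)c3nccnc3c2)CC1=O` gives 0.717 h there. Compound 2 holds the higher of the two numbers, and the gap lies beyond the scatter. Compound 3 `CN1CCC(CNC(=O)c2ccncc2Nc2cc(-c3ccc4ccn(C)c4c3)c3nccnc3c2)C1` carries (1-methylpyrrolidin-3-yl)methyl in place of 1-methyl-2-oxopiperidin-4-yl on an amide-type nitrogen and is otherwise unchanged from compound 2. Among the measured compounds shown here, no measured step covers this change, so the direction is a judgement. In this assay a downward step of about the size of the scatter is expected, and the estimated step is a 1.8-fold lower number from compound 2 to compound 3 (0.25 log units; within the scatter) on this reading. Compound 3 is estimated at 0.4 h with 0.17 h to 0.9 h as the expected range.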

Compound 3, half-life: > 1 h
Compound 3: no number, only a limit; the forecaster's own chance of this, stated with the estimate: 3%; middle value at least 2.5-fold (0.39 log units) away from the limit.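

Among the compounds shown here, at this amide-type nitrogen, (1-methylpyrrolidin-3-yl)methyl in place of 1-methyl-2-oxopiperidin-4-yl gives the first step on this position in this assay, an at least 1.3-fold higher number from compound 2 to compound 3 (0.14 log units; that floor lies within the scatter). Compound 3 gives > 1 h, which is a limit of the assay and not a number. The step therefore has only a floor, and its full size cannot be read because the value sits at that limit: the limit of > 1 h in this assay, at which 1 of the 3 values shown sits.

Which part of the change carries the step stays open: the ring carbonyl, the ring size or the methylene link. From the compounds shown here alone, how 1-methylpiperidin-4-yl on the same nitrogen would read also stays open.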